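Working notes: chain length and the step to compound 4

The source may report more compounds than this note shows. Statements on the series, on what has been measured and on what is new or still open speak of the compounds shown alone.

Compound 1 `CCCCCCCCCc1ccc(NC(=O)Nc2c(C(C)C)cccc2C(C)C)cc1` gives 9 nM in an assay on isolated protein for inhibition of acyl-CoA:cholesterol acyltransferase (Oryctolagus cuniculus); a higher number here means a weaker inhibitor, a lower number a stronger inhibitor. Compound 2 `CCCCCCCc1ccc(NC(=O)Nc2c(C(C)C)cccc2C(C)C)cc1` gives 19 nM, and compound 3 `CCCCCCCCCCCCCc1ccc(NC(=O)Nc2c(C(C)C)cccc2C(C)C)cc1` gives 11 nM. Compound 3 stands second highest of the three numbers, yet its gaps to compound 1 and to compound 2 both lie within the scatter. Compound 4 `CCCc1ccc(NC(=O)Nc2c(C(C)C)cccc2C(C)C)cc1` differs from compound 3 by hydrogen in place of decyl on a saturated chain carbon, three bonds along the chain from an aromatic carbon, leaving a chain shorter than in any measured compound. Of the measured steps, a 2.1-fold higher number from compound 1 to compound 2 (0.32 log units; beyond the scatter) is the only one beyond the scatter, while a 1.7-fold lower number from compound 2 to compound 3 (0.24 log units; within the scatter) stays within it. Cutting the chain much further is therefore expected to raise the number, probably by more than that earlier step. For compound 4 the estimate is 200 nM (range 50 nM to 800 nM), an expected step of an 18-fold higher number from compound 3 to compound 4 (1.26 log units; beyond the scatter).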

Compound 4, half-maximal inhibitory concentration: 38 nM
For compound 4 the middle estimate is 5.3-fold (0.72 log units) above the measured one, and the stated range ends above it.
By their numbers in this assay, from the lowest: compounds 1, 3, 2 and 4 (each within the scatter of the next, the first and the last beyond it).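

Cutting the chain back to the shortest one in the series costs little for so large a change, with a 3.5-fold higher number from compound 3 to compound 4 (0.54 log units; beyond the scatter) and a 4.2-fold higher number from compound 1 to compound 4 (0.63 log units; beyond the scatter), while a 2.0-fold higher number from compound 2 to compound 4 (0.30 log units; within the scatter) is not a resolved difference. Much of the chain can therefore go while compound 4 still gives 38 nM. The same change read at two chain lengths agrees: the same change on two cores in this assay, a 1.7-fold lower number (0.24 log units; within the scatter) from compound 2 to compound 3 and a 4.2-fold lower number (0.63 log units; beyond the scatter) from compound 4 to compound 1, 2.4-fold (0.39 log units) apart, within the scatter of two such steps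

Going by these compounds, whether methyl, an amine or a carboxylic acid in place of decyl at this carbon would raise the number further stays open.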